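Chloro in Place of Bromo on the Arylidene Arm

The compounds below may be only part of what the source reports. "The series", "measured", "known", "first", "only" and "open" are said of these compounds alone.

Compound 1 `O=C1/C(=C\c2c(Cl)cccc2Cl)c2ccccc2N1c1c(Cl)cccc1Cl`, compound 2 `COc1ccc(/C=C2\C(=O)N(c3c(Cl)cccc3Cl)c3ccccc32)cc1` and compound 3 `O=C1/C(=C\c2cccc(Br)c2)c2ccccc2N1c1c(Cl)cccc1Cl` share one core and differ only in the aryl group carried on the double-bonded chain carbon. In a functional assay on MIA PaCa-2 cells (Homo sapiens) for cytotoxicity, read by MTT assay, with a stated time of 72 h (on this read-out higher numbers stand for an effect only at larger amounts of compound and lower numbers for an effect already at smaller amounts), compound 1 gives > 100 ug/mL, which is a limit of the assay and not a number. In this assay compound 2 gives > 100 ug/mL, again a limit. Within the data shown here, compound 3 gives 5 ug/mL, the only number among the three. The step of an at least 20-fold lower number from compound 1 to compound 3 (1.30 log units; beyond the scatter) and the step of an at least 20-fold lower number from compound 2 to compound 3 (1.30 log units; beyond the scatter) both descend from the limit of > 100 ug/mL in this assay, at which 2 of the 3 values shown sit, to that number, whereas a step that the two limits leave unreadable from compound 1 to compound 2 cannot be read. Compound 4 `O=C1/C(=C\c2cccc(Cl)c2)c2ccccc2N1c1c(Cl)cccc1Cl` differs from compound 3 by chloro in place of bromo on an aromatic carbon. Among the measured compounds shown here, neither readable step exchanges one halogen for another on that ring; both replace the whole aryl group, so no measured step speaks directly to this change. The estimate for compound 4 is 5 ug/mL, between 2 ug/mL and 15 ug/mL. The step of no change at the digits printed from compound 3 to compound 4 (within the scatter) that this estimate means is expected to stay within the scatter.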

Compound 4, concentration for half-maximal effect: 5 ug/mL
The estimate for compound 4 equals the measured number at the digits printed, and the stated range covers the measured number.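

With compound 4, the exchange of one halogen for another on an aromatic carbon, meta to a large group, is measured directly: in this assay, chloro in place of bromo gives no change at the digits printed from compound 3 to compound 4 (within the scatter). The readable number is therefore not tied to bromo alone, and the 3-chlorophenyl arm also stands apart from the other two aryl groups, with an at least 20-fold lower number from compound 2 to compound 4 (1.30 log units; beyond the scatter) and an at least 20-fold lower number from compound 1 to compound 4 (1.30 log units; beyond the scatter). Both of these steps start from a limit of the assay and not from a number: the limit of > 100 ug/mL in this assay, at which 2 of the 4 values shown sit.

The compounds shown leave open whether fluoro, iodo, an amine or a carboxylic acid at this place would keep the number. They also leave open how far either halogen depends on this place on the ring, since each has been shown here at only one.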